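Working notes on compounds 1 to 4

The source may report more compounds than this note shows. Statements on the series, on what has been measured and on what is new or still open speak of the compounds shown alone.

Measured in an assay on isolated protein for inhibition of DNA topoisomerase 1 (Homo sapiens), with a stated time of 30 min, tested at 20 uM; a higher number here means a stronger effect of the compound at the concentration tested, a lower number a weaker effect:
- compound 1 `Cc1ccc2c(=O)[nH]c(-c3ccccc3C)nc2c1`: 39.2%
- compound 2 `Cc1ccc2nc(-c3cccc(C(F)(F)F)c3)[nH]c(=O)c2c1`: 4.2%
- compound 3 `O=c1[nH]c(-c2cccc3ccccc23)nc2ccc(N3CCCCC3)cc12`: 33.4%

Compound 1 has the highest of the three numbers in this assay. Its gap to compound 3 lies within the usual scatter, so the two cannot be put in order; its gap to compound 2 lies beyond the scatter, with compound 2 clearly the weaker of that pair. For the measured compounds named here, no two measured compounds differ in a single place, so no step between measured compounds is available to guide the next estimate.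

Compound 4 `Cc1ccc2c(=O)[nH]c(-c3ccccc3N(C)C)nc2c1` is still to be measured in this assay. It differs from compound 1 as follows: dimethylamino in place of methyl on an aromatic carbon. Going by the values given here, with no comparable step in hand, the expectation is a step of no more than the scatter, in either direction, from compound 1 to compound 4, and the estimate is a number 6.2 percentage points lower from compound 1 to compound 4 (within the scatter). Compound 4 is therefore expected to give about 33%, within a range from 10% to 56%.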

Compound 4, a percentage reported as inhibition, at one concentration (the size of the read-out at that concentration, not a potency): 5.3%
Compound 4: the middle estimate sits 27.7 percentage points above what was measured; measured number below the stated range.
By their numbers in this assay, from the lowest: compounds 2 and 4 (each within the scatter of the next); then compounds 3 and 1 (each within the scatter of the next).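

In this assay, for the compounds shown here, the change at this position gives the first readable single-place step: with dimethylamino in place of methyl on an aromatic carbon, ortho to a large group, the result is a number 33.9 percentage points lower from compound 1 to compound 4 (beyond the scatter). The position is therefore not indifferent to the group it carries, since replacing methyl (1 heavy atom, no hydrogen-bond acceptor) with dimethylamino (3 heavy atoms, 1 hydrogen-bond acceptor, no net charge) is enough to produce a step of this size. No measurement at hand explains the step.

This single step cannot separate the effect of the added carbon atoms from that of the nitrogen; an ethyl group, an isopropyl group or a methoxy group at the same place would help tell them apart. From the compounds shown here alone, whether an unsubstituted amine behaves like dimethylamino also remains open.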